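The source may hold more compounds than are shown below. What is called first, only, known or untested is meant among the compounds shown, and "the series" means these compounds.

Within the data shown here, compound 3 `CNc1ccc(-c2c3c(nn2C(C)C)CCNCC3)cc1` gives 16 nM in an ADME assay on membranes from Cortex for displacement of a labelled ligand from Adrenergic receptor alpha-1 (Rattus norvegicus), read by radioligand binding, with a stated time of 60 min (on this read-out higher numbers stand for weaker inhibition and lower numbers for stronger inhibition), the second highest of the three numbers measured so far. Compound 1 `Cc1ccc(-c2c3c(nn2C(C)C)CCNCC3)cc1` gives 4 nM in this assay, and compound 2 `CC(C)n1nc2c(c1-c1ccc(F)cc1)CCNCC2` gives 170 nM. Compound 4 `CC(C)n1nc2c(c1-c1ccc(C#N)cc1)CCNCC2` carries cyano in place of methylamino on an aromatic carbon. Among the measured compounds shown here, two measured steps touch the methylamino group directly: a 4.0-fold higher number from compound 1 to compound 3 (0.60 log units; beyond the scatter) and an 11-fold lower number from compound 2 to compound 3 (1.03 log units; beyond the scatter). A third, a 43-fold higher number from compound 1 to compound 2 (1.63 log units; beyond the scatter), shows how far the number moved when another small group replaced methyl at the same place. For the measured compounds named here, no measured compound carries a cyano group, so the direction of the step rests on these three precedents alone. Compound 4 is therefore expected to show a 7.5-fold higher number from compound 3 to compound 4 (0.88 log units; beyond the scatter) in this assay. Compound 4 is estimated at 120 nM in this assay, within a range of 25 nM to 600 nM.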

Compound 4, inhibition constant: 240 nM
Compound 4: the middle estimate sits 2.0-fold (0.30 log units) below what was measured; measured number inside the range.
By their numbers in this assay, from the lowest: compound 1; then compound 3; then compounds 2 and 4 (each within the scatter of the next).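

In this assay, cyano in place of methylamino gives a 15-fold higher number from compound 3 to compound 4 (1.18 log units; beyond the scatter) and cyano in place of methyl gives a 60-fold higher number from compound 1 to compound 4 (1.78 log units; beyond the scatter) at this place on the aromatic ring. Cyano in place of fluoro gives only a 1.4-fold higher number from compound 2 to compound 4 (0.15 log units; within the scatter), so these two groups cannot be told apart here, and both sit well apart from methyl and methylamino. Nothing given here accounts for this split. Still open, going by these compounds, is whether an unsubstituted amine, an ethyl group or a carboxylic acid at this place would fall with compound 1 and compound 3 or with compound 2 and compound 4.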